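The source may report more compounds than this note shows. Statements on the series, on what has been measured and on what is new or still open speak of the compounds shown alone.

Measured so far:
compound 1, `C=CC1=C(C(=O)NCCCCC)C(c2ccc(OC)cc2)OC1`: in a functional assay on A549 cells (Homo sapiens) for cytotoxicity, read by MTT assay, with a stated time of 24 h (a higher number here means a weaker inhibitor, a lower number a stronger inhibitor), compound 1 gives 36500 nM.
compound 2, `C=CC1=C(C(=O)NCc2ccccc2F)C(c2ccc(F)cc2)OC1`: compound 2 gives only the limit > 100000 nM.
compound 3, `C=CC1=C(C(=O)NCCC)C(c2ccc(F)cc2)OC1`: compound 3 gives only the limit > 100000 nM.

Among the measured compounds shown here, compound 1 holds the only number; the other two values are limits, so compound 1 cannot be ranked against them beyond the fact that it gave a reading where they did not. Two of the three values sit at the limit of > 100000 nM in this assay, at which 2 of the 3 values shown sit. The step that the two limits leave unreadable from compound 2 to compound 3 is therefore not readable, and it concerns a different place in any case.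

Compound 4, `C=CC1=C(C(=O)Nc2ccccc2)C(c2ccc(OC)cc2)OC1`, differs from compound 1 by phenyl in place of pentyl on an amide-type nitrogen. For the measured compounds named here, no measured step changes the group on the amide-type nitrogen between two readable values, so the data offer no guide to the size or direction of this step; the general weakness of the series is the only anchor. Compound 4 is therefore estimated at 45000 nM, within 15000 nM to 135000 nM, a step of a 1.2-fold higher number from compound 1 to compound 4 (0.09 log units; within the scatter) that is expected to stay within the usual scatter, with a fair chance that only a limit is returned.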

Compound 4, half-maximal inhibitory concentration: > 100000 nM
Compound 4: a limit, no number; the forecaster's own chance of this, stated with the estimate: 40%; at least 2.2-fold (0.34 log units) between middle value and limit.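

In this assay, among the compounds shown here, phenyl in place of pentyl on an amide-type nitrogen gives the first readable step at this position, towards weaker inhibition: an at least 2.7-fold higher number from compound 1 to compound 4 (0.43 log units; beyond the scatter). The value of compound 4, > 100000 nM, is a limit and not a number, so the step has a known lower bound but no known full size. Compound 1 remains the only compound with a number, and the series now sits mostly at the limit: the limit of > 100000 nM in this assay, at which 3 of the 4 values shown sit.

On these data alone, it remains open whether pentyl itself matters or whether other saturated chains on this nitrogen would also give a reading. A longer chain such as heptyl, or a chain ending in an amine, would test this on the core of compound 1, and any reading would have to be compared with that of compound 1, which gives 36500 nM.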